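This account rests on a few compounds, and the source may have more. Where it says the series, first, only, none or still open, it means among the compounds named here.

Compound 3 `CCCCCCCCc1cccc(N2CCNCC2)n1` is measured in a functional assay on the whole organism with Mus musculus as the target, in the maximal electroshock model, with a stated time of 120 min (on this read-out higher numbers stand for an effect only at larger amounts of compound and lower numbers for an effect already at smaller amounts), at 10 mg/kg. Compound 1 `CCCc1cccc(N2CCNCC2)n1` gives 10 mg/kg, and the two stand level at the digits shown, together the lowest of the three numbers, since no change at the digits printed from compound 1 to compound 3 (within the scatter). Compound 2 `CCCCSc1cccc(N2CCNCC2)n1` gives 100 mg/kg, and a 10-fold higher number from compound 1 to compound 2 (1.00 log units; beyond the scatter). Compound 4 `CCCCCc1cccc(N2CCNCC2)n1` differs from compound 3 by hydrogen in place of propyl on a saturated chain carbon, five bonds along the chain from an aromatic carbon. Going by the values given here, the step that bears on this is the one from compound 1 to compound 3, where a longer chain on the same core left the number unchanged within the scatter; no other measured pair speaks to chain length. Compound 4 is therefore expected to show no change at the digits printed from compound 3 to compound 4 (within the scatter), and its estimated value is 10 mg/kg with a range from 5 mg/kg to 25 mg/kg.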

Compound 4, minimum effective dose: 10 mg/kg
Beside the measured number, compound 4's estimate shows no gap at the digits printed, within the range that was stated.
By their numbers in this assay, from the lowest: compounds 1, 3 and 4 (each within the scatter of the next); then compound 2.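

In this assay, hydrogen in place of propyl five bonds along the chain gives no change at the digits printed from compound 3 to compound 4 (within the scatter), and the shorter change on compound 1 gives no change at the digits printed from compound 1 to compound 4 (within the scatter), so no step among these alkyl chains on the shared core lies beyond the scatter. Pentyl in place of butylsulfanyl on an aromatic carbon gives a 10-fold lower number from compound 2 to compound 4 (1.00 log units; beyond the scatter), a second alkyl comparison that sets compound 2 apart. Nothing measured here explains either result. As far as these compounds go, whether methyl, an amine or a carboxylic acid on this aromatic carbon would keep the number remains open.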